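This account rests on a few compounds, and the source may have more. Where it says the series, first, only, none or still open, it means among the compounds named here.

Measured so far in a functional assay on HepG2 cells (Homo sapiens) for cytotoxicity, read by MTT assay, with a stated time of 48 h; on this read-out higher numbers stand for weaker inhibition and lower numbers for stronger inhibition:
compound 1 `CCCCCCCCCCCCNC(=O)[C@@H](NC(=O)c1nccc2ccccc12)[C@@H](C)O` gives 65700 nM
compound 2 `CCCCCCCCCCCCNC(=O)[C@@H](NC(=O)c1cc2ccccc2[nH]1)[C@@H](C)O` gives 12000 nM
compound 3 `CCCCCCCCCCCCCCCCCCNC(=O)[C@@H](NC(=O)c1nccc2ccccc12)[C@@H](C)O` gives 96900 nM

Compound 2 differs from compound 1 by 1H-indol-2-yl in place of isoquinolin-1-yl on a carbonyl carbon; on this assay that gave a 5.5-fold lower number from compound 1 to compound 2 (0.74 log units; beyond the scatter). Compound 3 differs from compound 1 by hexyl in place of hydrogen on a saturated chain carbon, ten or more bonds along the chain from an amide-type nitrogen, and that change gave only a 1.5-fold higher number from compound 1 to compound 3 (0.17 log units; within the scatter). With two pairs only, no pattern beyond these three compounds is claimed.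

Compound 4 `CCCCCCCCCCCCCCCCCCNC(=O)[C@@H](NC(=O)c1cc2ccccc2[nH]1)[C@@H](C)O` has not yet been measured. It differs from compound 3 by 1H-indol-2-yl in place of isoquinolin-1-yl on a carbonyl carbon, which is the same change as that from compound 1 to compound 2, made at the same place; the two cores differ as described above for compound 3 against compound 1. Within the data shown here, the step from compound 3 to compound 4 on this assay is expected to be a 4.8-fold lower number from compound 3 to compound 4 (0.69 log units; beyond the scatter), close to the earlier one, because a 1.5-fold higher number from compound 1 to compound 3 (0.17 log units; within the scatter) shows the longer chain by itself changed little and the core change is the one that moved the number. On this assay compound 4 is therefore expected to give about 20000 nM, with a likely range from 8000 nM to 50000 nM.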

Compound 4, half-maximal inhibitory concentration: 89400 nM
For compound 4 the middle estimate is 4.5-fold (0.65 log units) below the measured one, and the stated range ends below it.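

In this assay the change to 1H-indol-2-yl from isoquinolin-1-yl gave a 1.1-fold lower number from compound 3 to compound 4 (0.03 log units; within the scatter), so the step seen on the core of compound 1 did not carry over to the core of compound 3: the same change on two cores in this assay, a 5.5-fold lower number (0.74 log units; beyond the scatter) from compound 1 to compound 2 and a 1.1-fold lower number (0.03 log units; within the scatter) from compound 3 to compound 4, 5.1-fold (0.70 log units) apart, beyond the scatter of two such steps. Read the other way, the added hexyl gave a 7.5-fold higher number from compound 2 to compound 4 (0.87 log units; beyond the scatter), and this step also differs from the one on the core of compound 1: the same change on two cores in this assay, a 1.5-fold higher number (0.17 log units; within the scatter) from compound 1 to compound 3 and a 7.5-fold higher number (0.87 log units; beyond the scatter) from compound 2 to compound 4, 5.1-fold (0.70 log units) apart, beyond the scatter of two such steps. The two changes are thus not additive across these four compounds, and neither step can be moved from one core to the other as a fixed increment, but a single set of four compounds does not show how either change behaves on any other core.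

The compounds shown leave open how the step from isoquinolin-1-yl to 1H-indol-2-yl behaves on a shorter chain or on one of intermediate length. Also open, from the compounds shown here alone, is how it behaves on a chain carrying a terminal amine or carboxylic acid.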